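A few compounds are considered here, and "the series" means these few. Any claim that something is new, unique, unknown or untested is made for them only; others in the source may bear on it.

Measured compounds:
compound 1 `N#Cc1ccc(Nc2nccc(OCc3cccc(Cl)c3)n2)cc1` with 153000 nM
compound 2 `Cc1ccccc1COc1ccnc(Nc2ccc(C#N)cc2)n1` with 12000 nM

In an ADME assay on MT4 cells (Homo sapiens) for cytotoxicity, read by MTT assay, with a stated time of 5 days (a higher number here means that more compound is tolerated, a lower number that less compound is tolerated), compound 1 stands highest of the two numbers, and compound 2 gives 12000 nM. For the measured compounds named here, the one measured step is a 13-fold lower number from compound 1 to compound 2 (1.11 log units; beyond the scatter), a large drop beyond the scatter. Compound 3 `N#Cc1ccc(Nc2nccc(OCc3ccccc3C#N)n2)cc1` differs from compound 1 by 2-cyanophenyl in place of 3-chlorophenyl on a saturated chain carbon bound to an oxygen on an aromatic ring. That step swaps the same group as the measured one, but the group that enters is a different one, so a smaller drop is expected. Compound 3 is therefore estimated at 60000 nM, between 15000 nM and 200000 nM, which would mean an expected 2.6-fold lower number from compound 1 to compound 3 (0.41 log units; beyond the scatter).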

Compound 3, half-maximal cytotoxic concentration: 113000 nM
For compound 3 the middle estimate is 1.9-fold (0.27 log units) below the measured one; low and high end bracket the measured number.
By their numbers in this assay, from the lowest: compound 2; then compounds 3 and 1 (each within the scatter of the next).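

In this assay the 2-cyanophenyl group on a saturated chain carbon bound to an oxygen on an aromatic ring gives a 1.4-fold lower number from compound 1 to compound 3 (0.13 log units; within the scatter) so this position can accept a replacement of 3-chlorophenyl without a change beyond the scatter. Cyano in place of methyl on an aromatic carbon gives a 9.4-fold higher number from compound 2 to compound 3 (0.97 log units; beyond the scatter) so among these three compounds the low number goes with the methyl group alone. No supporting evidence bears on why these two groups differ. Going by these compounds, whether an amine or a carboxylic acid on that ring would follow cyano or methyl stays open.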